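This account rests on a few compounds, and the source may have more. Where it says the series, first, only, none or still open, it means among the compounds named here.

Measured compounds:
- Compound 1 `Nc1nc(NC2CC2)c2ncn(/C=C3/CC3(CO)CO)c2n1`: > 20000 nM
- Compound 2 `Nc1nc(NC2CCCCC2)c2ncn(/C=C3/CC3(CO)CO)c2n1`: "not determined" (no result reported)

In an ADME assay on MOLT-3 cells (Homo sapiens) for cytotoxicity, with a stated time of 7 days (on this read-out lower numbers stand for higher toxicity in this test and higher numbers for lower toxicity in this test), compound 1 gives > 20000 nM, and this is a limit of the assay rather than a number. Compound 2 has no value of its own here; of the two results shown, one sits at the limit of > 20000 nM in this assay, at which 1 of the 2 values shown sits, so nothing places compound 2 on a scale. Compound 3 `Nc1nc(SCc2ccccc2)c2ncn(/C=C3/CC3(CO)CO)c2n1` differs from compound 2 by one change: benzylsulfanyl in place of cyclohexylamino on an aromatic carbon. For the measured compounds named here, no step between measured compounds exists in this assay, so no measured direction can be carried over. With only a limit among the measured compounds, no step beyond the scatter is expected in this assay. Compound 3 is expected to give roughly 20000 nM in this assay, within 8000 nM to 60000 nM, most likely again reported as a limit.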

Compound 3, half-maximal cytotoxic concentration: > 20000 nM
Compound 3: a limit, no number; the forecaster's own chance of this, stated with the estimate: 75%; the middle value sits exactly at the limit.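

No new step can be read from compound 1 to compound 3, because both results are limits of the assay rather than numbers: the limit of > 20000 nM in this assay, at which 2 of the 3 values shown sit. The compounds shown leave open whether any group on this aromatic carbon gives a measurable number in this assay.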